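The source may hold more compounds than are shown below. What is called first, only, known or untested is meant among the compounds shown, and "the series" means these compounds.

Compound 1 `CC(C)OC(=O)N1CCC(CCCC(=O)c2ncco2)CC1` gives 4 nM in an assay on isolated protein for inhibition of Fatty-acid amide hydrolase 1 (Homo sapiens); a lower number here means a stronger inhibitor, a higher number a weaker inhibitor. Compound 2 `Cc1cccc(CN2CCC(CCCC(=O)c3ncco3)CC2)c1` gives 90 nM in this assay. Compound 3 `COc1cccc(CN2CCC(CCCC(=O)c3ncco3)CC2)c1` gives 34 nM in this assay.

Compound 3 holds the second highest number of the three. Its nearest neighbour is compound 2, separated from it by a 2.6-fold lower number from compound 2 to compound 3 (0.42 log units; beyond the scatter), and the furthest is compound 1, which lies well below it; the gap between compound 1 and compound 2 is a 23-fold higher number from compound 1 to compound 2 (1.35 log units; beyond the scatter), the widest step seen here.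

Compound 4 `O=C(CCCC1CCN(Cc2ccccc2Br)CC1)c1ncco1` differs from compound 3 by 2-bromophenyl in place of 3-methoxyphenyl on a saturated chain carbon bound to an amine nitrogen in a ring. For the measured compounds named here, no measured pair covers this exchange of one ring substituent for another of a different kind on the same saturated chain carbon. Going by the values given here, the only step within the benzyl series, a 2.6-fold lower number from compound 2 to compound 3 (0.42 log units; beyond the scatter), is a modest one, and the two benzyl compounds, compound 2 and compound 3, sit within a narrow band of each other. Compound 4 is therefore expected to remain in that band, with a 1.8-fold higher number from compound 3 to compound 4 (0.25 log units; within the scatter) as the estimated change in this assay, in the direction of a somewhat higher number. The estimate for compound 4 in this assay is 60 nM, with a range from 15 nM to 250 nM.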

Compound 4, half-maximal inhibitory concentration: 315 nM
Compound 4: middle estimate off by 5.3-fold (0.72 log units), on the low side; measured number outside the range, above it.
By their numbers in this assay, from the lowest: compound 1; then compound 3; then compound 2; then compound 4.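

In this assay, the aryl group on the saturated chain carbon bound to an amine nitrogen in a ring matters more than the earlier benzyl pair suggested: a 9.3-fold higher number from compound 3 to compound 4 (0.97 log units; beyond the scatter) is clearly larger than a 2.6-fold lower number from compound 2 to compound 3 (0.42 log units; beyond the scatter) within that pair. The 2-bromophenyl group also separates compound 4 from the 3-methylphenyl compound, with a 3.5-fold higher number from compound 2 to compound 4 (0.54 log units; beyond the scatter) as the step, so the benzyl compounds no longer form a narrow band, while a 79-fold higher number from compound 1 to compound 4 (1.90 log units; beyond the scatter) widens the distance from the isopropoxycarbonyl compound and leaves compound 4 as the weakest inhibitor of the four. No evidence on the origin of these rises is available here.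

Compound 4 differs from compound 2 and compound 3 in both the substituent and where it stands on the phenyl ring, so the compounds shown cannot separate these two changes. A 3-bromophenyl or a 2-methoxyphenyl group in the same place would address that question, and an unsubstituted phenyl group would show whether any ring substituent is needed at all.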